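The source may report more compounds than this note shows. Statements on the series, on what has been measured and on what is new or still open speak of the compounds shown alone.

Of the compounds shown here, three of a shared core have been measured in a physicochemical assay for solubility, read by HPLC, in simulated intestinal fluid, with a stated time of 16 h, tested at 125 ug/mL; on this read-out higher numbers stand for higher solubility and lower numbers for lower solubility. Compound 1 `CNC(=O)c1cc(C(=O)NC2CC2)cn([C@H](C)c2ccccc2)c1=O` gives 815 ug/mL, the second highest of the three numbers. Compound 2 `CNC(=O)c1cc(C(=O)NC2CCC2)cn(Cc2ccccn2)c1=O` gives 920 ug/mL, which lies within the scatter of compound 1. Going by the values given here, compound 3 `CNC(=O)c1cc(C(=O)NC2CCC2)cn(Cc2ccncc2)c1=O` gives 121 ug/mL, the one value that falls clearly away: a 7.6-fold lower number from compound 2 to compound 3 (0.88 log units; beyond the scatter).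

Compound 4 `CNC(=O)c1cc(C(=O)NC2CC2)cn(Cc2ccccc2F)c1=O` differs from compound 1 in one place: 2-fluorobenzyl in place of 1-phenylethyl on an aromatic nitrogen. Among the compounds with values here, no measured step touches this kind of change, since the only step in hand swaps one pyridinyl group for another on the same sort of carbon. Without a bearing step, the expected step is a 1.2-fold lower number from compound 1 to compound 4 (0.07 log units; within the scatter), none beyond the scatter, and compound 4 is estimated at 700 ug/mL, from 300 ug/mL to 1400 ug/mL.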

Compound 4, solubility: 88 ug/mL
Beside the measured number, compound 4's estimate is 8.0-fold (0.90 log units) above it, outside the stated range (below it).
By their numbers in this assay, from the lowest: compounds 4 and 3 (each within the scatter of the next); then compounds 1 and 2 (each within the scatter of the next).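

Swapping 1-phenylethyl for 2-fluorobenzyl on the aromatic nitrogen gives a 9.3-fold lower number from compound 1 to compound 4 (0.97 log units; beyond the scatter) in this assay even though both groups have 8 heavy atoms, one six-membered aromatic ring of carbon only and no hydrogen-bond donors or acceptors. The swap also removes the defined stereocentre and brings in a fluorine, and these two differences cannot be told apart here. Nothing measured here gives a reason for this step. Still open, on these data alone, is whether plain benzyl, with no fluorine and no stereocentre, or 1-(2-fluorophenyl)ethyl, which keeps both, would read closer to compound 1 or to compound 4.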